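The compounds below may be only part of what the source reports. "The series", "measured", "known", "first", "only" and "open" are said of these compounds alone.

Working notes on the series. Compound 2 `CC(C)c1ccc(CN2CCc3nc(-c4ccccn4)nc(N4CCN(CCN(C)C)CC4)c3C2)cc1` gives 57.2% in an assay on FRT cells with Cystic fibrosis transmembrane conductance regulator variant F508del (Homo sapiens) as the target, read by fluorescence, with a stated time of 25 min (on this read-out lower numbers stand for smaller maximal responses and higher numbers for larger maximal responses), the only numerical entry so far; compound 1 `CN(C)CCN1CCN(c2nc(-c3ccccn3)nc3c2CN(Cc2ccc(F)cc2)CC3)CC1` is the only other entry and in this assay it is recorded as "not active" (no number reported), without a number. Compound 3 `CN(C)CCN1CCN(c2nc(-c3ccccn3)nc3c2CN(S(=O)(=O)c2ccccc2)CC3)CC1` is not yet measured. Relative to compound 2 the change is phenylsulfonyl in place of 4-isopropylbenzyl on an amine nitrogen in a ring. Among the compounds with values here, no step between two measured compounds is available to gauge what such a change does here, and compound 1 shows that a different group at the same place can leave the response unreported. A downward step is expected rather than one within the scatter, with the estimate for compound 3 in this assay at 30%, ranging from 5% to 60%, because compound 1 at "not active" (no number reported) shows the series can lose its response. The expected change is a number 27.2 percentage points lower from compound 2 to compound 3 (beyond the scatter).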

Compound 3, largest response reached (Emax), in percent of the reference or control that the assay uses: "not active" (no number reported)
Compound 3: no number reported; no gap can be computed for the estimate.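

Within the data shown here, with no number reported for compound 3, no step from compound 2 to compound 3 can be read in this assay. Nothing available bears on this result. The compounds shown leave open how far the response of compound 2 depends on its 4-isopropylbenzyl group.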